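The source may hold more compounds than are shown below. What is called first, only, known or untested is meant among the compounds shown, and "the series" means these compounds.

In a functional assay on KBVIN cells (Homo sapiens) for antiproliferative activity, read by sulforhodamine B assay, with a stated time of 3 days (on this read-out lower numbers stand for an effect already at smaller amounts and higher numbers for an effect only at larger amounts of compound), compound 1 `CCCc1ccc(-c2cc(=O)c3c(o2)C(CC)(CC)C(=O)C(CC)=C3O)cc1` gives 12.2 uM and compound 2 `CCC1=C(O)c2c(oc(-c3ccc(OC)c(C)c3)cc2=O)C(CC)(CC)C1=O` gives 0.1 uM, the lower of the two numbers. Compound 3 `CCC1=C(O)c2c(oc(-c3ccc(O)c(O)c3)cc2=O)C(CC)(CC)C1=O` has not yet been measured. It carries 3,4-dihydroxyphenyl in place of 4-methoxy-3-methylphenyl on an aromatic carbon, next to the ring oxygen: 3,4-dihydroxyphenyl in place of 4-methoxy-3-methylphenyl on an aromatic carbon. Among the measured compounds shown here, one measured step bears on this change, at the same carbon: a 120-fold lower number from compound 1 to compound 2 (2.09 log units; beyond the scatter), with 4-methoxy-3-methylphenyl in place of 4-propylphenyl. That large step shows how far the number in this assay can move when this group alone is exchanged. For the measured compounds named here, no measured compound yet carries 3,4-dihydroxyphenyl, and 4-methoxy-3-methylphenyl holds the lower number so far, so a higher number is expected on leaving it. The step is expected to be smaller than the measured one. The estimated step is a 15-fold higher number from compound 2 to compound 3 (1.18 log units; beyond the scatter). For compound 3 the estimate is 1.5 uM, with an expected range from 0.3 uM to 8 uM.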

Compound 3, concentration for half-maximal effect: 5.41 uM
Estimate against measurement, compound 3: 3.6-fold (0.56 log units) below, within the range that was stated.
By their numbers in this assay, from the lowest: compound 2; then compound 3; then compound 1.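

In this assay the exchange of 4-methoxy-3-methylphenyl for 3,4-dihydroxyphenyl on this aromatic carbon gives a 54-fold higher number from compound 2 to compound 3 (1.73 log units; beyond the scatter) and so undoes most of the large step seen earlier. Set against 4-propylphenyl, the same 3,4-dihydroxyphenyl gives only a 2.3-fold lower number from compound 1 to compound 3 (0.35 log units; beyond the scatter) which is beyond the scatter but modest, so among the three groups 4-methoxy-3-methylphenyl stands well apart, while the other two lie much closer to each other. Nothing measured here accounts for these differences.

The compounds shown do not separate the contribution of the methoxy from that of the methyl within 4-methoxy-3-methylphenyl. They also leave open where the number would fall with an amine or a carboxylic acid on this phenyl ring.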